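A few compounds are considered here, and "the series" means these few. Any claim that something is new, unique, unknown or untested is made for them only; others in the source may bear on it.

In a functional assay on HL-60 cells (Homo sapiens) for inhibition, read by resazurin assay, with a stated time of 72 h (a higher number here means a weaker inhibitor, a lower number a stronger inhibitor), compound 2 `CCOc1ccc(C2C(Oc3ccccc3)C(=O)N2c2cc(OC)c(OC)c(OC)c2)cc1` gives 494 nM. Going by the values given here, compound 2 stands second highest of the three numbers measured so far: nearest is compound 3 `CCSc1ccc(C2C(Oc3ccccc3)C(=O)N2c2cc(OC)c(OC)c(OC)c2)cc1`, which in this assay gives 508 nM, and furthest is compound 1 `COc1cc(N2C(=O)C(O)C2c2ccc(SC)cc2)cc(OC)c1OC`, which in this assay gives 15 nM. Among the compounds with values here, the single step between measured compounds that differ in one place, a 1.0-fold higher number from compound 2 to compound 3 (0.01 log units; within the scatter), brings ethylsulfanyl in place of ethoxy on an aromatic carbon and leaves the number essentially where it was. The step to compound 4 `CCOc1ccc(C2CC(=O)N2c2cc(OC)c(OC)c(OC)c2)cc1` is of a different kind: hydrogen in place of phenoxy on a saturated ring carbon. Within the data shown here, no measured step bears directly on this change, since compound 1 differs from compound 2 both at the saturated ring carbon and on the aromatic ring, so its far lower number cannot be assigned to either change alone. Compound 4 is estimated to give 120 nM in this assay, with a range from 25 nM to 600 nM. That estimate means an expected step of a 4.1-fold lower number from compound 2 to compound 4 (0.61 log units; beyond the scatter) toward a lower number, leaning on the fact that compound 1 reaches 15 nM without a phenoxy group, but held with wide uncertainty.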

Compound 4, half-maximal inhibitory concentration: 88 nM
For compound 4 the middle estimate is 1.4-fold (0.13 log units) above the measured one; measured number inside the range.
By their numbers in this assay, from the lowest: compound 1; then compound 4; then compounds 2 and 3 (each within the scatter of the next).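

In this assay, going by these compounds alone, the step of a 5.6-fold lower number from compound 2 to compound 4 (0.75 log units; beyond the scatter) isolates this saturated ring carbon for the first time: phenoxy gives way to hydrogen while the 4-ethoxyphenyl group and the rest of the shared core stay unchanged. Within the data shown here, compounds 2 and 3 both carry phenoxy, and compound 1 differs from compound 2 in two places, so none of the earlier comparisons could separate this change from the others. The step shows that phenoxy is not needed for activity in this series and that its replacement by hydrogen gives the stronger inhibitor of this pair, although no evidence is available to explain the difference.

On these data alone, whether an amine or a methoxy group on this carbon would give a lower or higher number remains open. As far as these compounds go, it is also open whether the change would have a similar size with ethylsulfanyl in place of ethoxy.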